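A few compounds are considered here, and "the series" means these few. Any claim that something is new, unique, unknown or untested is made for them only; others in the source may bear on it.

Measured compounds:
- compound 1 `N#CCC(=O)Nc1csc(-c2ccc(Cl)c(Cl)c2)c1` gives 10000 nM in a physicochemical assay for solubility, measured as kinetic solubility, with a stated time of 1 h, at pH 7.4; a higher number here means a more soluble compound, a lower number a less soluble compound
- compound 2 `O=C1CCCC(C(=O)NC2=NN(c3ccc(Cl)c(Cl)c3)CC2)N1` gives 416000 nM in this assay

Among the compounds with values here, of the two numbers so far, compound 2 stands at the top: compound 1 sits far beneath it, and that gap is well beyond the ordinary scatter of repeated measurements. The two compounds share little beyond the dichlorophenyl group, so this gap says nothing yet about single changes.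

Compound 3 `O=C(NC1=NN(c2ccc(Cl)c(Cl)c2)CC1)c1cncnc1` has not been measured. It keeps the core of compound 2 and changes only the group on the carbonyl carbon: pyrimidin-5-yl in place of 6-oxopiperidin-2-yl on a carbonyl carbon. A saturated, partly polar ring with an amide hydrogen gives way to a flat aromatic ring that carries no hydrogen-bond donor. Such a change is expected to lower the measured solubility, and by more than the scatter, though without a measured pair of this kind the size of the step is uncertain. The step from compound 2 to compound 3 is estimated at a 6.9-fold lower number from compound 2 to compound 3 (0.84 log units; beyond the scatter). Compound 3 is therefore expected to give about 60000 nM in this assay, within a range from 12000 nM to 250000 nM.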

Compound 3, solubility: 8000 nM
The estimate for compound 3 lay 7.5-fold (0.88 log units) above the measured number; measured number outside the range, below it.
By their numbers in this assay, from the lowest: compounds 3 and 1 (each within the scatter of the next); then compound 2.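

Compound 2 and compound 1 differ in too many places to show what any single group contributes, but this pair isolates one place, the group on a carbonyl carbon whose other neighbour is an amide-type nitrogen. In this assay, putting pyrimidin-5-yl in place of 6-oxopiperidin-2-yl gives a 52-fold lower number from compound 2 to compound 3 (1.72 log units; beyond the scatter) and so shows that, with the rest of the structure unchanged, the number is highly sensitive to the group at this place. The exchange alters several things at once, including a non-aromatic ring for an aromatic one and a group with 1 hydrogen-bond donor for one with 0, and nothing available explains which of these differences accounts for the step.

The compounds shown leave open which of those differences matters, as a phenyl ring or a piperidin-2-yl ring without the ring carbonyl at this place would help to separate them. They also leave open how an open chain ending in an amine or a carboxylic acid would behave here, and whether the step would keep its size on a different core.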